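A few compounds are considered here, and "the series" means these few. Any claim that something is new, unique, unknown or untested is made for them only; others in the source may bear on it.

Measured so far in a functional assay on the whole organism (strain Wistar) for inhibition, with Rattus norvegicus as the target, read by paw edema, with stated times of 30 min and 60 min, at a dose of 50 mg/kg by the oral route; a higher number here means more inhibition at the dose given (going by the name of the read-out), a lower number less inhibition:

Compound 1 `Cc1ccc(C2=NN(c3ccc([N+](=O)[O-])cc3)C(c3cn(-c4ccccc4)nc3-c3ccc(Cl)c(Cl)c3)C2)cc1`: 72.5%
Compound 2 `O=[N+]([O-])c1ccc(N2N=C(c3ccc(F)cc3)CC2c2cn(-c3ccccc3)nc2-c2ccc(Cl)c(Cl)c2)cc1`: 60.3%
Compound 3 `O=[N+]([O-])c1ccc(N2N=C(c3ccc(Cl)cc3)CC2c2cn(-c3ccccc3)nc2-c2ccc(Cl)c(Cl)c2)cc1`: 57.3%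

Among these three, compound 1 stands highest, with compound 2 nearest and compound 3 furthest; both of those gaps lie beyond the scatter. The two steps away from compound 1 were a number 12.2 percentage points lower from compound 1 to compound 2 (beyond the scatter) and a number 15.2 percentage points lower from compound 1 to compound 3 (beyond the scatter), while the step of a number 3 percentage points lower from compound 2 to compound 3 (within the scatter) stays within the scatter.

Compound 4 `Cc1ccc(C2=NN(C=O)C(c3cn(-c4ccccc4)nc3-c3ccc(Cl)c(Cl)c3)C2)cc1` has not yet been measured in this assay. It differs from compound 1 in one place: formyl in place of 4-nitrophenyl on an amine nitrogen in a ring. Among the measured compounds shown here, none of the measured steps touches this place; all three alter the substituent on the 4-methylphenyl ring, so they say nothing direct about what removing the 4-nitrophenyl group does. The change itself is large in the count of atoms lost, so the expectation is wide. Compound 4 is estimated at 55%, with a range from 35% to 75%. Relative to compound 1 this would be an expected step of a number 17.5 percentage points lower from compound 1 to compound 4 (beyond the scatter).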

Compound 4, a percentage reported as inhibition, in the whole organism at one dose (the size of the read-out at that dose, not a potency): 53.4%
Compound 4: the middle estimate sits 1.6 percentage points above what was measured, and the stated range covers the measured number.
By their numbers in this assay, from the lowest: compounds 4, 3 and 2 (each within the scatter of the next); then compound 1.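

In this assay, among the compounds shown here, the change of 4-nitrophenyl to formyl on the amine nitrogen in a ring gives a number 19.1 percentage points lower from compound 1 to compound 4 (beyond the scatter), the first step at this place, since the earlier steps altered only the group on the 4-methylphenyl ring. The 4-nitrophenyl group therefore matters to the read-out, yet it is not required for a response: with only formyl there, compound 4 still gives 53.4% at the dose tested. No measurement at hand explains the step.

The compounds shown leave open whether the step follows from losing the nitro group or the whole aromatic ring, which a plain phenyl group on that nitrogen would separate. They also leave open how an acetyl group would compare with formyl, and whether the step would hold with fluoro or chloro in place of the methyl.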